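Ethoxycarbonyl for hydroxymethyl on a covalent pyrazole series

The source may report more compounds than this note shows. Statements on the series, on what has been measured and on what is new or still open speak of the compounds shown alone.

Compound 1 `O=C(CCl)Nc1ccc(Cn2nc(-c3ccc(Oc4ccccc4)cc3)cc2CO)cc1` is the reference point of this small set. In a functional assay on Z-138 cells (Homo sapiens) for inhibition, read by luminescence and CellTiter-Glo, with a stated time of 72 h (a higher number here means a weaker inhibitor, a lower number a stronger inhibitor), compound 1 gives 400 nM, the lowest of the two numbers reported. Compound 2 `C/C=C/C(=O)Nc1cccc(Cn2nc(-c3ccc(Oc4ccccc4)cc3)cc2C(=O)O)c1` carries a carboxylic acid on the shared core together with a different amide and a different attachment of the benzyl arm, and in this assay compound 2 gives 24100 nM, a gap from compound 1 that lies well beyond the scatter of repeated runs. Compound 3 `C=CC(=O)N1CCCC(n2nc(-c3ccc(Oc4ccccc4)cc3)cc2C(=O)O)C1` replaces the benzyl arm with a piperidine bearing an acrylamide while keeping the acid, and for compound 3 this assay reports only a limit, > 60000 nM. One of the three values therefore sits at the limit of > 60000 nM in this assay, at which 1 of the 3 values shown sits, rather than at a number.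

The step to be followed leads from compound 1 to compound 4 `CCOC(=O)c1cc(-c2ccc(Oc3ccccc3)cc2)nn1Cc1ccc(NC(=O)CCl)cc1`, which keeps the chloroacetamide and the benzyl attachment of compound 1 and changes one group on the core: ethoxycarbonyl in place of hydroxymethyl on an aromatic carbon. Among the measured compounds shown here, no measured pair in the set differs in only this place, so the size of the step is not yet known. Given that both acid-bearing compounds lie far above compound 1, the expectation is a weakening in this assay, moderate rather than drastic, which is summarised as a 3.8-fold higher number from compound 1 to compound 4 (0.57 log units; beyond the scatter). Compound 4 is estimated at 1500 nM, with a plausible range from 300 nM to 8000 nM.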

Compound 4, half-maximal inhibitory concentration: 400 nM
The estimate for compound 4 lay 3.8-fold (0.57 log units) above the measured number; low and high end bracket the measured number.
By their numbers in this assay, from the lowest: compounds 1 and 4 (each within the scatter of the next); then compound 2. At a limit, above all of these: compound 3.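

Exchanging hydroxymethyl for ethoxycarbonyl on this aromatic carbon of the shared core gives, in this assay, no change at the digits printed from compound 1 to compound 4 (within the scatter). Among the compounds shown here, this is the first comparison in the set that isolates this position: compounds 2 and 3 differ from compound 1 in more than one place, so their numbers could not speak to this group alone, whereas compound 4 shows that, with the chloroacetamide and benzyl attachment kept, the place accepts a group of 5 heavy atoms with 0 hydrogen-bond donors in place of one of 2 heavy atoms with 1 donor, without a change beyond the scatter. Nothing measured in this set offers a cause for this result.

The compounds shown leave open how a carboxylic acid at this place would read with the chloroacetamide and the benzyl attachment of compound 1 kept, as the acid in compound 2 and compound 3 always comes with other differences. They also leave open whether an amine, a primary amide or a longer ester chain at this place would keep the number of compound 1.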